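Swapping a nitrophenyl for a chlorophenyl on a dihydropyridine

A few compounds are considered here, and "the series" means these few. Any claim that something is new, unique, unknown or untested is made for them only; others in the source may bear on it.

Of the compounds shown here, two that share one core have been measured in a functional assay on aorta with Voltage-dependent L-type calcium channel subunit alpha-1C (Oryctolagus cuniculus) as the target; on this read-out higher numbers stand for a longer-lived compound and lower numbers for a shorter-lived compound. Compound 1, with the structure `CC1=NC(C)=C(C(=O)OCCCN2C(=O)c3ccccc3S2(=O)=O)C(c2cccc([N+](=O)[O-])c2)/C1=C(\O)OC(C)C`, carries a 3-nitrophenyl group on a saturated ring carbon of its core; in this assay compound 1 gives 0.0783 h. Compound 2, with the structure `CCO/C(O)=C1\C(C)=NC(C)=C(C(=O)OCCCN2C(=O)c3ccccc3S2(=O)=O)C1c1ccccc1C(F)(F)F`, carries a 2-(trifluoromethyl)phenyl group at the same kind of position and a different ester; in this assay compound 2 gives 0.155 h. Compound 1 has the lower of the two numbers, but the gap to compound 2 lies within the usual scatter of repeated measurements, so the two values cannot be told apart.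

Compound 3, with the structure `CC1=NC(C)=C(C(=O)OCCCN2C(=O)c3ccccc3S2(=O)=O)C(c2ccccc2Cl)/C1=C(\O)OC(C)C`, differs from compound 1 in one place: 2-chlorophenyl in place of 3-nitrophenyl on a saturated ring carbon. Among the compounds with values here, no step between two measured compounds covers this change, so nothing measured shows how it acts here. The step of a 1.3-fold higher number from compound 1 to compound 3 (0.11 log units; within the scatter) is therefore expected to stay within the scatter, with no clear direction. On that basis compound 3 is estimated to give 0.1 h in this assay, with a plausible range from 0.04 h to 0.25 h.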

Compound 3, half-life: 0.08 h
The estimate for compound 3 lay 1.3-fold (0.10 log units) above the measured number; the range from low to high includes it.
By their numbers in this assay, from the lowest: compounds 1, 3 and 2 (each within the scatter of the next).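

In this assay, within the data shown here, replacing the 3-nitrophenyl group with 2-chlorophenyl on the saturated ring carbon gives a 1.0-fold higher number from compound 1 to compound 3 (0.01 log units; within the scatter), and this is the only direct reading of a change at this position, since compound 2 differs from compound 1 in its ester as well. Within this single pair, the half-life therefore does not separate a group of 9 heavy atoms with 2 hydrogen-bond acceptors from one of 7 heavy atoms with none, although one pair cannot show that this position tolerates every change. Nothing available accounts for this result.

The compounds shown leave open whether a phenyl ring bearing an amine or a carboxylic acid at this carbon would also stay within the scatter of compound 1, or whether a clear step would appear. They also leave open whether the swap from 3-nitrophenyl to 2-chlorophenyl would read the same with an ethyl ester or a longer chain in place of the ester on the core of compound 1.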